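The source may hold more compounds than are shown below. What is called first, only, known or untested is meant among the compounds shown, and "the series" means these compounds.

Compound 1, `CCCc1ccc(Nc2ccc3c(c2)C(=O)N(C2CCC(=O)NC2=O)C3=O)cc1`, gives 10% in an assay on FRT-Jurkat cells for inhibition of nuclear factor NF-kappa-B complex (Homo sapiens), read by flow cytometry, with a stated time of 24 h, tested at 10 uM; a higher number here means more inhibition at the concentration tested (going by the name of the read-out), a lower number less inhibition.
Compound 2, `CCc1ccc(Nc2ccc3c(c2)C(=O)N(C2CCC(=O)NC2=O)C3=O)cc1`, gives 5% in this assay.

Compound 2 holds the lower of these two readings, yet a number 5 percentage points lower from compound 1 to compound 2 (within the scatter), so the two compounds cannot be told apart. Compound 3, `CC(C)(C)c1ccc(Nc2ccc3c(c2)C(=O)N(C2CCC(=O)NC2=O)C3=O)cc1`, differs from compound 2 by tert-butyl in place of ethyl on an aromatic carbon. Within the data shown here, the one measured step, hydrogen in place of methyl on the chain, a number 5 percentage points lower from compound 1 to compound 2 (within the scatter); it changes the same chain by one carbon, but no measured step matches the present change, so it bears on it only loosely. The expected step of a number 3 percentage points higher from compound 2 to compound 3 (within the scatter) is therefore none beyond the scatter. Compound 3 is estimated at 8%, within 0% to 25%.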

Compound 3, a percentage reported as inhibition, at one concentration (the size of the read-out at that concentration, not a potency): 17%
For compound 3 the middle estimate is 9 percentage points below the measured one, within the range that was stated.
By their numbers in this assay, from the lowest: compounds 2, 1 and 3 (each within the scatter of the next, the first and the last beyond it).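

Among these compounds, on the aromatic carbon para to a large group, tert-butyl in place of ethyl gives a number 12 percentage points higher from compound 2 to compound 3 (beyond the scatter), the only step so far that clears the scatter, and a modest one. Tert-butyl in place of propyl gives a number 7 percentage points higher from compound 1 to compound 3 (within the scatter), so the branched group can be told apart from ethyl but not from propyl. Nothing available explains this difference.

The compounds shown leave open whether a longer chain, a methoxy group or an amine at this position would change the reading. They also leave open whether a tert-butyl group placed elsewhere on the ring would do the same.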